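Working notes: compound 3 to compound 4 in the series

A few compounds are considered here, and "the series" means these few. Any claim that something is new, unique, unknown or untested is made for them only; others in the source may bear on it.

Compound 3 `CC[C@@H](Nc1c(C#N)c(-c2ccc(-c3ccccc3COC)cc2)nc2cnccc12)C(N)=O` gives 2.6 in a physicochemical assay for lipophilicity, read by HPLC, at pH 7.5 (on this read-out lower numbers stand for lower lipophilicity and higher numbers for higher lipophilicity), the lowest of the three numbers in hand. Its nearest neighbour is compound 2 `CC[C@@H](Nc1c(C#N)c(-c2ccc(-c3ccc(OC)cc3)cc2)nc2cnccc12)C(N)=O`, which in this assay gives 2.7; the step of a number 0.10 log units lower from compound 2 to compound 3 (within the scatter) lies within the scatter. Compound 1 `CC[C@@H](Nc1c(C#N)c(-c2ccc(-c3cccc(C)c3F)cc2)nc2cnccc12)C(N)=O` gives 3 in this assay; the step of a number 0.40 log units lower from compound 1 to compound 3 (beyond the scatter) is the only one in the set beyond the scatter, while a number 0.30 log units lower from compound 1 to compound 2 (within the scatter) stays within it.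

Compound 4 `CC[C@@H](Nc1c(C#N)c(-c2ccc(-c3cccc(OC)c3)cc2)nc2cnccc12)C(N)=O` differs from compound 3 by 3-methoxyphenyl in place of 2-(methoxymethyl)phenyl on an aromatic carbon. The step that bears on this change is the one in which 4-methoxyphenyl gave way to 2-(methoxymethyl)phenyl, a number 0.10 log units lower from compound 2 to compound 3 (within the scatter), within the scatter. Compound 4 brings a methoxyphenyl back in place of the methoxymethyl-bearing group, so the expectation in this assay is a small rise at most, no step beyond the scatter, estimated as a number 0.10 log units higher from compound 3 to compound 4 (within the scatter). Compound 4 is therefore expected to give about 2.7 in this assay, within a range of 2.4 to 3.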

Compound 4, distribution coefficient: 2.7
Beside the measured number, compound 4's estimate shows no gap at the digits printed, within the range that was stated.
By their numbers in this assay, from the lowest: compounds 3, 2, 4 and 1 (each within the scatter of the next, the first and the last beyond it).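

Two methoxyphenyl isomers can now be compared in this assay: 3-methoxyphenyl in place of 4-methoxyphenyl gives no change at the digits printed from compound 2 to compound 4 (within the scatter) and so shows no separation between them, while the change from 2-(methoxymethyl)phenyl gives a number 0.10 log units higher from compound 3 to compound 4 (within the scatter) and likewise stays inside the scatter. Within the data shown here, measured against 2-fluoro-3-methylphenyl, the 3-methoxyphenyl group gives a number 0.30 log units lower from compound 1 to compound 4 (within the scatter) and so remains within the scatter, as 4-methoxyphenyl does, which leaves 2-(methoxymethyl)phenyl as the only group in the set with a step from compound 1 beyond the scatter. Nothing in hand offers an explanation for these numbers.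

Still open, going by these compounds, is whether 2-methoxyphenyl on this aromatic carbon would fall within the same narrow band. Also open, on these data alone, is how far an aminomethyl or carboxylic acid substituent on this ring would shift the read-out in this assay from the values seen so far.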